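The compounds below may be only part of what the source reports. "The series", "measured", "known", "first", "only" and "open" are said of these compounds alone.

For the measured compounds named here, in a functional assay on MCF7 cells (Homo sapiens) for inhibition, read by MTT assay, with a stated time of 72 h (a lower number here means a stronger inhibitor, a higher number a weaker inhibitor), compound 1 (`COc1cc(NC(=O)/C=C/c2cccc(OCc3ccccc3)c2)cc(OC)c1OC`) gives 2400 nM, the lowest of the three numbers measured so far. The open question is compound 4 (`COc1cc(NC(=O)/C=C/c2cccc(N)c2)cc(OC)c1OC`), which keeps the core of compound 1 but carries amino in place of benzyloxy on an aromatic carbon, meta to a large group: amino in place of benzyloxy on an aromatic carbon. Going by the values given here, only one measured step exists, a 1.1-fold higher number from compound 2 to compound 3 (0.04 log units; within the scatter). It lies within the scatter and involves a different exchange, (trifluoromethyl)sulfanyl in place of hydrogen, so it offers no direct guide here. Among the compounds with values here, no measured pair shows the loss of benzyloxy. Compound 2 (`C=C(Br)C(=O)Nc1cccc(/C=C/C(=O)Nc2ccccc2)c1`), at 27300 nM, and compound 3 (`C=C(Br)C(=O)Nc1cccc(/C=C/C(=O)Nc2ccc(SC(F)(F)F)cc2)c1`), at 30100 nM, also carry no benzyloxy, and both numbers are higher than that of compound 1, though these compounds differ from it elsewhere too. This supports only a weak expectation of a weaker inhibitor. The expected change is a 2.9-fold higher number from compound 1 to compound 4 (0.46 log units; beyond the scatter), towards a higher number. Compound 4 is estimated at 7000 nM, with an expected range from 1500 nM to 30000 nM.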

Compound 4, half-maximal inhibitory concentration: 55400 nM
Estimate against measurement, compound 4: 7.9-fold (0.90 log units) below; the whole stated range lies below it.
By their numbers in this assay, from the lowest: compound 1; then compounds 2, 3 and 4 (each within the scatter of the next, the first and the last beyond it).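

In this assay, for the compounds shown here, putting amino in place of benzyloxy on this aromatic carbon gives a 23-fold higher number from compound 1 to compound 4 (1.36 log units; beyond the scatter), a large step and the first measured exchange at this place on the core of compound 1. Going by these compounds alone, with the rest of the molecule unchanged, the position therefore does not tolerate this exchange without a large loss of inhibition, which the earlier compounds, differing from compound 1 elsewhere too, could not show. No supporting data are available to account for the size of this step.

The exchange removes the six-membered aromatic ring and the oxygen and brings in amino all at once, and the compounds shown cannot separate these changes. Going by these compounds, whether a benzylamino group, a methoxy group or a longer chain ending in a phenyl ring would keep the number of compound 1 remains open.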